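Swapping the Ring Amide for a Sulfonamide

The source may report more compounds than this note shows. Statements on the series, on what has been measured and on what is new or still open speak of the compounds shown alone.

Compound 1 `COc1cc(C(F)(F)F)cc(C(F)(F)F)c1C(=O)NC1(c2ccccc2)CCCN(Cc2ccccc2)C1`: 6700 nM
Compound 2 `COc1cc(C(F)(F)F)cc(C(F)(F)F)c1C(=O)NC1(c2ccccc2)CCCN(C(C)=O)C1`: a limit, > 10000 nM
Compound 3 `COc1cc(C(F)(F)F)cc(C(F)(F)F)c1C(=O)NC1(c2ccccc2)CCCN(C(=O)c2ccccc2)C1`: a limit, > 10000 nM

These three compounds share one core and differ only in the group on an amine nitrogen in a ring. In an assay on cells for inhibition of sodium- and chloride-dependent glycine transporter 1 (Homo sapiens) (on this read-out lower numbers stand for an effect already at smaller amounts and higher numbers for an effect only at larger amounts of compound), compound 1 gives 6700 nM. Compound 2 reaches only the limit of this assay, > 10000 nM. Compound 3 likewise sits at a limit, > 10000 nM. Compound 3 thus stands at the limit of > 10000 nM in this assay, at which 2 of the 3 values shown sit, the weakest reading the assay records; the relevant measured steps are an at least 1.4-fold higher number from compound 1 to compound 2 (0.17 log units; that floor lies within the scatter) and an at least 1.4-fold higher number from compound 1 to compound 3 (0.17 log units; that floor lies within the scatter), while a step that the two limits leave unreadable from compound 2 to compound 3.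

Compound 4 `COc1cc(C(F)(F)F)cc(C(F)(F)F)c1C(=O)NC1(c2ccccc2)CCCN(S(C)(=O)=O)C1` carries methylsulfonyl in place of benzoyl on an amine nitrogen in a ring. Both measured replacements of benzyl pushed the number to the limit, so compound 4 is expected to stay there too, a step that the limit leaves unreadable from compound 3 to compound 4. The estimate for compound 4 is 15000 nM, between 5000 nM and 50000 nM.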

Compound 4, half-maximal effective concentration: > 10000 nM
Compound 4 gave a limit, no number; the forecaster's own chance of this, stated with the estimate: 75%; the middle value does not contradict the limit.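

Methylsulfonyl joins acetyl and benzoyl on this amine nitrogen, so a sulfonyl group ends at the same limit as the two carbonyl groups, and only compound 1 gives a number: the limit of > 10000 nM in this assay, at which 3 of the 4 values shown sit.

Among these compounds, the one readable step is an at least 1.4-fold higher number from compound 1 to compound 4 (0.17 log units; that floor lies within the scatter), so the true size of the change stays unknown. The steps among compound 2, compound 3 and compound 4 cannot be read.

Still open, on these data alone, is whether a plain methyl or a longer chain such as phenylethyl on this nitrogen would give a readable number.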